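The source may report more compounds than this note shows. Statements on the series, on what has been measured and on what is new or still open speak of the compounds shown alone.

Of the compounds shown here, three built on one shared core have so far been tested in a functional assay on CFPAC-1 cells (Homo sapiens) for antiproliferative activity, read by MTT assay, with a stated time of 72 h; a higher number here means a weaker inhibitor, a lower number a stronger inhibitor. Compound 3 `CCCCCc1ccc(-c2cn(C[C@H](O)[C@H]3OC(=O)C(OCc4ccccc4)=C3OCc3ccccc3)nn2)cc1` gives 9890 nM, the lowest of the two numbers shown. Compound 1 `O=C1O[C@H]([C@@H](O)Cn2cc(CNS(=O)(=O)c3ccc(Cl)cc3F)nn2)C(OCc2ccccc2)=C1OCc1ccccc1` gives 58200 nM. Compound 2 `COc1ccccc1-c1cn(C[C@H](O)[C@H]2OC(=O)C(OCc3ccccc3)=C2OCc2ccccc2)nn1` reaches only a limit of the assay, > 100000 nM. Within the data shown here, the single step measured within this set, an at least 10-fold lower number from compound 2 to compound 3 (1.00 log units; beyond the scatter), shows that the arrival of the 4-pentylphenyl group goes with a strong fall in the number. Compound 4 `O=C1O[C@H]([C@@H](O)Cn2cc(CCCCl)nn2)C(OCc2ccccc2)=C1OCc1ccccc1` is not yet measured; it differs from compound 3 by 3-chloropropyl in place of 4-pentylphenyl on an aromatic carbon. This removes the very group whose arrival brought that large fall, so a rise beyond the scatter is expected, though the incoming chain is unlike anything measured here and the size is uncertain. Compound 4 is therefore estimated at 40000 nM, between 12000 nM and 100000 nM. That corresponds to an expected step of a 4.0-fold higher number from compound 3 to compound 4 (0.61 log units; beyond the scatter).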

Compound 4, half-maximal inhibitory concentration: 58800 nM
For compound 4 the middle estimate is 1.5-fold (0.17 log units) below the measured one; measured number inside the range.
By their numbers in this assay, from the lowest: compound 3; then compounds 1 and 4 (each within the scatter of the next). At a limit, above all of these: compound 2.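

Losing the 4-pentylphenyl group for 3-chloropropyl gives a 5.9-fold higher number from compound 3 to compound 4 (0.77 log units; beyond the scatter), so a low number at this position depends on which group sits there. Putting 2-chloroethyl in place of ((4-chloro-2-fluorophenyl)sulfonyl)amino on a saturated chain carbon bound to an aromatic carbon gives a 1.0-fold higher number from compound 1 to compound 4 (0.00 log units; within the scatter). Putting 3-chloropropyl in place of 2-methoxyphenyl on an aromatic carbon gives an at least 1.7-fold lower number from compound 2 to compound 4 (0.23 log units; that floor lies within the scatter), and this floor is all that can be read of that step. Compound 2 stands at a limit: the limit of > 100000 nM in this assay, at which 1 of the 4 values shown sits.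

Still open, as far as these compounds go, is whether the benzene ring or the pentyl chain of compound 3 matters more. A plain phenyl group and a longer unbranched alkyl chain at this position would separate the two.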